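A Larger Group on the Shared Core

This account rests on a few compounds, and the source may have more. Where it says the series, first, only, none or still open, it means among the compounds named here.

Measured compounds so far:
compound 1, `c1ccc(-c2nn(-c3ccccc3)cc2-c2nc3ccccc3[nH]2)cc1`, 2710 nM
compound 2, `Cc1ccc2[nH]c(-c3cn(-c4ccccc4)nc3-c3ccccc3)nc2c1`, 3610 nM
compound 3, `FC(F)(F)c1ccc2[nH]c(-c3cn(-c4ccccc4)nc3-c3ccccc3)nc2c1`, 5930 nM

Of the compounds shown here, three built on one shared core have been tested in a functional assay on A549 cells (Homo sapiens) for antiproliferative activity, read by MTT assay, with a stated time of 48 h; on this read-out lower numbers stand for stronger inhibition and higher numbers for weaker inhibition. Compound 1 shows the lowest of the three numbers. Compound 2 sits close to it: a 1.3-fold higher number from compound 1 to compound 2 (0.12 log units; within the scatter). Compound 3 lies further off: a 2.2-fold higher number from compound 1 to compound 3 (0.34 log units; beyond the scatter). Between the two substituted compounds, a 1.6-fold higher number from compound 2 to compound 3 (0.22 log units; within the scatter).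

Compound 4, `O=C(OCc1ccccc1)c1ccc2[nH]c(-c3cn(-c4ccccc4)nc3-c3ccccc3)nc2c1`, has not yet been measured. It differs from compound 1 in a single place: benzyloxycarbonyl in place of hydrogen on an aromatic carbon. Both measured steps that start from compound 1 alter this same position, and both ended at a number equal to or higher than the starting point; the methyl step stayed within the scatter, while the trifluoromethyl step was modest but beyond it. Neither group placed there lowered the number. The benzyloxycarbonyl group brings in many more atoms than either earlier group, so the trifluoromethyl step is taken as the closer guide. A modest rise is therefore expected in this assay, and the estimated step is a 2.4-fold higher number from compound 1 to compound 4 (0.38 log units; beyond the scatter). Compound 4 is expected to give about 6500 nM, with a likely range from 2700 nM to 16000 nM.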

Compound 4, half-maximal inhibitory concentration: 19300 nM
Estimate against measurement, compound 4: 3.0-fold (0.47 log units) below, outside the stated range (above it).
By their numbers in this assay, from the lowest: compounds 1, 2 and 3 (each within the scatter of the next, the first and the last beyond it); then compound 4.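

The position on the aromatic carbon of a six-membered aromatic ring of carbon only is not indifferent to what it carries: in this assay, methyl and trifluoromethyl shifted the number only slightly, but benzyloxycarbonyl gives a clearly larger step, a 7.1-fold higher number from compound 1 to compound 4 (0.85 log units; beyond the scatter). The change also stands out against the two smaller substituents, with a 3.3-fold higher number from compound 3 to compound 4 (0.51 log units; beyond the scatter) and a 5.3-fold higher number from compound 2 to compound 4 (0.73 log units; beyond the scatter), so compound 4 is the weakest of the four in this assay, its steps to all the others lying beyond the scatter. Nothing available here bears on why the number rose.

These four compounds cannot show whether the rise follows the overall size of the group or comes from a particular part of it, such as the carbonyl or the added aromatic ring. A carboxylic acid, a methyl ester or a simple amide at the same carbon would help separate those parts, and would show whether any group there can bring the number below that of the unsubstituted compound 1.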